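This account rests on a few compounds, and the source may have more. Where it says the series, first, only, none or still open, it means among the compounds named here.

Among the measured compounds shown here, the series so far holds two compounds read in a functional assay on LOX IMVI cells (Homo sapiens) for cytotoxicity, read by resazurin assay, with a stated time of 72 h; on this read-out lower numbers stand for stronger inhibition and higher numbers for weaker inhibition. Compound 1 (`O=C(/C=C/c1ccc(OCCCCCO[N+](=O)[O-])c(O)c1)OCCCCCO[N+](=O)[O-]`) gives 7230 nM as a measured number. Compound 2 (`COc1cc(/C=C/C(=O)OCCCCCO[N+](=O)[O-])ccc1O`) gives > 50000 nM (a limit of the assay, not a number). Compound 2 therefore has no number of its own, and any step away from it can only be sized against that limit.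

Next in line is compound 3 (`COc1cc(/C=C/C(=O)OCCCCCO[N+](=O)[O-])ccc1OCCCCCO[N+](=O)[O-]`), which differs from compound 2 by a single change (5-(nitrooxy)pentyl in place of hydrogen on an oxygen on an aromatic ring): 5-(nitrooxy)pentyl in place of hydrogen on an oxygen on an aromatic ring. For the measured compounds named here, no measured step shows what this change does. Going by the values given here, the only measured number to lean on is that of compound 1 (7230 nM), so the expectation is a move toward stronger inhibition.

Expected in this assay is a sizeable move beyond the scatter, written as an at least 4.1-fold lower number from compound 2 to compound 3 (0.61 log units; beyond the scatter) and estimated against a limit rather than a number. The estimate for compound 3 is 12000 nM (expected range 3500 nM to 40000 nM).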

Compound 3, half-maximal inhibitory concentration: > 50000 nM
Compound 3: a limit, no number; the forecaster's own chance of this, stated with the estimate: 20%; middle value at least 4.1-fold (0.61 log units) away from the limit.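

In this assay compound 3 gives > 50000 nM, a limit of the assay and not a number. The step that adds 5-(nitrooxy)pentyl cannot be read, as the values at both ends are limits: the limit of > 50000 nM in this assay, at which 2 of the 3 values shown sit.

The readable comparison is with compound 1, where methyl in place of hydrogen on an oxygen on an aromatic ring gives an at least 6.9-fold higher number from compound 1 to compound 3 (0.83 log units; beyond the scatter), which is beyond the scatter, so keeping 5-(nitrooxy)pentyl on the ring oxygen does not by itself preserve a measurable value once that hydrogen is replaced by methyl.

Still open is how far this loss is specific to methyl, since compounds with ethyl or a longer chain ending in a carboxylic acid on that oxygen are not among those shown. Also open, as far as these compounds go, is what 5-(nitrooxy)pentyl contributes on its own, which would need a pair differing only in that group with a number at both ends, and whether a shorter chain carrying the same nitrooxy end would behave alike.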